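This account rests on a few compounds, and the source may have more. Where it says the series, first, only, none or still open, it means among the compounds named here.

Three compounds share one core and differ only in the group on the thiocarbonyl carbon. In a toxicity assay on HeLa cells (Homo sapiens) for cytotoxicity, read by MTT assay, with a stated time of 24 h (a lower number here means a stronger inhibitor, a higher number a weaker inhibitor), compound 1 `Cc1ncc([N+](=O)[O-])n1CC(O)CSC(=S)N1CCCC(C)C1` gives 609000 nM, compound 2 `Cc1ncc([N+](=O)[O-])n1CC(O)CSC(=S)N1CCC(C)CC1` gives 1820000 nM, and compound 3 `Cc1ncc([N+](=O)[O-])n1CC(O)CSC(=S)N1CCCCCC1` gives 411000 nM. Compound 3 has the lowest number of the three: the step of a 1.5-fold lower number from compound 1 to compound 3 (0.17 log units; within the scatter) lies within the scatter, while the step of a 4.4-fold lower number from compound 2 to compound 3 (0.65 log units; beyond the scatter) is beyond the scatter though modest. Compound 4 `CCN(C)C(=S)SCC(O)Cn1c([N+](=O)[O-])cnc1C` is not yet measured; it differs from compound 3 by ethyl(methyl)amino in place of azepan-1-yl on a thiocarbonyl carbon. Among the compounds with values here, every measured step here swaps one ring for another at this position, and the largest of them, a 3.0-fold higher number from compound 1 to compound 2 (0.48 log units; beyond the scatter), is still modest; no measured step replaces a ring with an open chain, so the comparison is indirect. The expected step in this assay is therefore small, a 1.6-fold higher number from compound 3 to compound 4 (0.20 log units; within the scatter), without a clear direction. The estimate for compound 4 is 650000 nM, within a range from 250000 nM to 1700000 nM.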

Compound 4, half-maximal inhibitory concentration: 4150000 nM
Compound 4: middle estimate off by 6.4-fold (0.81 log units), on the low side; measured number outside the range, above it.
By their numbers in this assay, from the lowest: compounds 3 and 1 (each within the scatter of the next); then compound 2; then compound 4.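

Swapping the azepan-1-yl ring for the open ethyl(methyl)amino chain on the thiocarbonyl carbon has a larger effect in this assay than any ring-for-ring swap shown, with a 10-fold higher number from compound 3 to compound 4 (1.00 log units; beyond the scatter) and a similarly large change in a 6.8-fold higher number from compound 1 to compound 4 (0.83 log units; beyond the scatter). Even the smallest of the new steps, a 2.3-fold higher number from compound 2 to compound 4 (0.36 log units; beyond the scatter), lies beyond the scatter, so all three ring compounds give lower numbers than the open-chain compound, which here means stronger cell toxicity. The data offer no measurement that explains this difference.

Compound 4 both loses the ring and has fewer heavy atoms than compound 3, so these two changes cannot be separated here. A small ring such as pyrrolidin-1-yl and a longer open chain such as dipropylamino would help tell them apart.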